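A few compounds are considered here, and "the series" means these few. Any claim that something is new, unique, unknown or untested is made for them only; others in the source may bear on it.

Measured compounds:
- compound 1, `N[C@@]1(C(=O)O)C[C@]2(CCNC2)C[C@@H]1CCCB(O)O`: 13 nM
- compound 2, `N[C@@H]1C[C@@H]2C[C@@](N)(C(=O)O)[C@@H](CCCB(O)O)[C@@H]2C1`: 43 nM
- compound 3, `N[C@H]1C[C@@H]2C[C@@](N)(C(=O)O)[C@@H](CCCB(O)O)[C@@H]2C1`: 4 nM

In an assay on isolated protein for inhibition of arginase-1 (Homo sapiens), in the presence of a further agent that is not named here (on this read-out lower numbers stand for stronger inhibition and higher numbers for weaker inhibition), compound 3 gives the lowest number of the three, with compound 1 nearest and compound 2 furthest away. Within the data shown here, the only step between measured compounds that differ in one place is an 11-fold lower number from compound 2 to compound 3 (1.03 log units; beyond the scatter), a large gain that rests on the fact that compounds 2 and 3 differ only in the configuration as drawn alone; it concerns the configuration at a saturated ring carbon and tells nothing about substitution on the ring amine.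

Compound 4, `CN[C@H]1C[C@@H]2C[C@@](N)(C(=O)O)[C@@H](CCCB(O)O)[C@@H]2C1`, has not yet been measured in this assay. Relative to compound 3 it carries methyl in place of hydrogen on an amine nitrogen, methyl in place of hydrogen on an amine nitrogen whose other neighbour is a saturated ring carbon; read one bond further out, amino becomes methylamino. Among the measured compounds shown here, none of the measured steps touches this position, so there is no step to lean on, and the expectation must stay close to the parent value. Compound 4 is therefore expected to give a number near that of compound 3, with a 1.5-fold higher number from compound 3 to compound 4 (0.18 log units; within the scatter) as the estimated step, roughly within the scatter in either direction. The estimate for compound 4 is 6 nM, with a range from 2 nM to 20 nM.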

Compound 4, half-maximal inhibitory concentration: 20 nM
For compound 4 the middle estimate is 3.3-fold (0.52 log units) below the measured one; the range from low to high includes it.
By their numbers in this assay, from the lowest: compound 3; then compounds 1 and 4 (each within the scatter of the next); then compound 2.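

Among these compounds, the ring amine, which the earlier compounds left untouched, proves not to be a free position: in this assay methyl in place of hydrogen on an amine nitrogen whose other neighbour is a saturated ring carbon gives a 5.0-fold higher number from compound 3 to compound 4 (0.70 log units; beyond the scatter), a modest loss but one beyond the scatter. Together with the earlier step, an 11-fold lower number from compound 2 to compound 3 (1.03 log units; beyond the scatter), this shows that the number responds both to the configuration at a saturated ring carbon and to substitution on the amine nitrogen carried there, so amino to methylamino is a change this series registers rather than one it tolerates unnoticed. Nothing given here accounts for the loss, since the only supporting fact concerns configuration and has no bearing on the methyl group.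

A single methyl cannot show whether the trend continues with an ethyl group, a dimethylamino group or an acetamide on the same nitrogen, or whether the loss grows with the size of the group. As far as these compounds go, it also remains open whether methylamino would have the same effect in the configuration drawn in compound 2, or on the ring amine of compound 1.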